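Swapping the aromatic group on the ring nitrogen

The source may hold more compounds than are shown below. What is called first, only, known or untested is meant among the compounds shown, and "the series" means these compounds.

Compound 1 `CN1CCN(CC(=O)Nc2nc3ccccc3[nH]2)CC1` and compound 2 `O=C(CN1CCN(c2ccccc2F)CC1)Nc1nc2ccccc2[nH]1` share the same core and differ only in the group on an amine nitrogen in a ring. In a functional assay, read by spectrophotometry, with a stated time of 30 min, tested at 50 ug/mL (a higher number here means a stronger effect of the compound at the concentration tested, a lower number a weaker effect), compound 1 gives 33.5%, while compound 2 gives 37.4%. Among the measured compounds shown here, of the two numbers measured, the one for compound 2 is the higher, but the gap to compound 1 is within the scatter, so the two compounds cannot really be told apart.

Compound 3 `COc1ccc(N2CCN(CC(=O)Nc3nc4ccccc4[nH]3)CC2)cc1` has not yet been measured. It differs from compound 2 as follows: 4-methoxyphenyl in place of 2-fluorophenyl on an amine nitrogen in a ring. For the measured compounds named here, only one measured step exists to draw on: a number 3.9 percentage points higher from compound 1 to compound 2 (within the scatter), which put an aromatic ring where a methyl had been. Going by the values given here, no step that exchanges one aromatic ring for another has been measured, so nothing here points either up or down. With only that to go on, the step of a number 0.4 percentage points lower from compound 2 to compound 3 (within the scatter) is expected to stay within the scatter. Compound 3 is therefore estimated at 37% in this assay, with a range from 22% to 52%.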

Compound 3, a percentage reported as activity, at one concentration (the size of the read-out at that concentration, not a potency): 25.8%
Compound 3: middle estimate off by 11.2 percentage points, on the high side; measured number inside the range.
By their numbers in this assay, from the lowest: compounds 3, 1 and 2 (each within the scatter of the next, the first and the last beyond it).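

This position does not treat all aromatic rings alike: in this assay there is a number 11.6 percentage points lower from compound 2 to compound 3 (beyond the scatter), and this modest step, the only one here beyond the scatter, exchanges one aromatic ring for another, a kind of change the earlier pair did not include. The ring itself still does not set compound 3 apart from the small methyl group, since the comparison with the methyl compound gives a number 7.7 percentage points lower from compound 1 to compound 3 (within the scatter), so these two cannot be told apart, and the difference shows only between the two aromatic groups. Nothing measured alongside these numbers accounts for the step between the two aromatic groups, so it stays unexplained.

The step swaps two things at once, the substituent on the aromatic ring and its place on that ring, so the compounds shown cannot separate the two; 4-fluorophenyl and 2-methoxyphenyl groups on the same ring nitrogen would pull them apart. Also open, on these data alone, is where an unsubstituted phenyl or a benzyl group would fall, and whether this step would hold at other concentrations, as each number here is a read-out at a single concentration.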